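From Isopropyl to Butyl on the Aromatic Ring

The source may hold more compounds than are shown below. What is called first, only, known or untested is meant among the compounds shown, and "the series" means these compounds.

Compound 1 `Cc1ccc(/C=C/C(=O)Nc2ccc3c(c2)OCCO3)cc1`: 210 nM
Compound 2 `CC(C)c1ccc(/C=C/C(=O)Nc2ccc3c(c2)OCCO3)cc1`: 55 nM

In a functional assay on CHO cells for inhibition of transient receptor potential cation channel subfamily V member 1 (Homo sapiens) (on this read-out higher numbers stand for weaker inhibition and lower numbers for stronger inhibition), compound 1 gives 210 nM, while compound 2 gives 55 nM. Among the compounds with values here, the one step measured so far, a 3.8-fold lower number from compound 1 to compound 2 (0.58 log units; beyond the scatter), shows that a larger alkyl group on the aromatic carbon went with stronger inhibition. On these two numbers compound 2 stands lowest, the stronger inhibitor of the pair.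

Compound 3 `CCCCc1ccc(/C=C/C(=O)Nc2ccc3c(c2)OCCO3)cc1` continues in the same direction: butyl in place of isopropyl on an aromatic carbon. Within the data shown here, only the step from compound 1 to compound 2 bears on this change, and it was modest. Butyl is a straight chain rather than a branched group, so the gain seen before need not repeat; a small further lowering, or none beyond the scatter, is expected. The expected step is a 1.2-fold lower number from compound 2 to compound 3 (0.09 log units; within the scatter). Compound 3 is therefore estimated at 45 nM, with a likely range from 15 nM to 150 nM.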

Compound 3, half-maximal inhibitory concentration: 360 nM
Estimate against measurement, compound 3: 8.0-fold (0.90 log units) below; the whole stated range lies below it.
By their numbers in this assay, from the lowest: compound 2; then compounds 1 and 3 (each within the scatter of the next).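

At this position on the aromatic ring, adding carbon does not keep strengthening inhibition in this assay: butyl in place of isopropyl gives a 6.5-fold higher number from compound 2 to compound 3 (0.82 log units; beyond the scatter) and reverses the earlier gain, so compound 3 goes against any simple rule that a larger alkyl group is better. Set against the smaller methyl group, butyl gives a 1.7-fold higher number from compound 1 to compound 3 (0.23 log units; within the scatter) and so brings no measurable gain, which leaves isopropyl as the only one of these three groups that clearly stands out. No measurement shown here explains this turn.

Still open, from the compounds shown here alone, is whether the branched shape of isopropyl or the length of the chain matters more, which a propyl or a tert-butyl group at this place could help to separate. These compounds also say nothing about how a methoxy group or an amine would fare there.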